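The source may report more compounds than this note shows. Statements on the series, on what has been measured and on what is new or still open speak of the compounds shown alone.

Compound 1, with the structure `O=C(C1CCOCC1)N1N=CCC1c1ccccc1`, is measured in a physicochemical assay for lipophilicity, read by HPLC, measured as chromatographic lipophilicity, at pH 7.4 (a higher number here means a more lipophilic compound, a lower number a more polar compound), where it gives 3.1. Among the three compounds with a number in this assay it stands lowest. Compound 3, with the structure `O=C(C1CCN(c2ccccn2)CC1)N1N=CC[C@H]1c1ccccc1`, is its nearest neighbour: in this assay compound 3 gives 5.1, a value above that of compound 1 and well beyond the scatter. Compound 2, with the structure `CC(C)(C)C(=O)n1nccc1-c1ccccc1`, lies furthest away: in this assay compound 2 gives 8.3, far above both of the others. No pair among these three differs in only one place, so no single step between measured compounds can be read off from them.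

Compound 4, with the structure `O=C(C1CCOC1)N1N=CCC1c1ccccc1`, has not yet been measured. It differs from compound 1 in one place: oxolan-3-yl in place of oxan-4-yl on a carbonyl carbon. A five-membered ring with one hetero atom replaces a six-membered ring with one hetero atom, the count of hydrogen-bond donors and acceptors staying the same. Among the measured compounds shown here, with no measured step of this kind to lean on, the change is expected to move the value only a little, if at all, and downward rather than upward. The step from compound 1 to compound 4 is estimated at a number 0.30 log units lower from compound 1 to compound 4 (within the scatter), a step that may well fall within the scatter. Compound 4 is therefore expected to give about 2.8, within a range from 2.3 to 3.3.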

Compound 4, distribution coefficient: 3
Compound 4: the middle estimate sits 0.20 log units below what was measured, within the range that was stated.
By their numbers in this assay, from the lowest: compounds 4 and 1 (each within the scatter of the next); then compound 3; then compound 2.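

Among the compounds shown here, the pair of compound 1 and compound 4 gives the first single step in this set, and in this assay it reads a number 0.10 log units lower from compound 1 to compound 4 (within the scatter) and so cannot be told apart from repeat measurement. For the compounds shown here, on a carbonyl carbon whose other neighbours are an amide-type nitrogen in a ring, oxolan-3-yl can therefore take the place of oxan-4-yl on the core of compound 1 with no detectable change in this read-out, something the earlier compounds, none of which differed in only one place, could not show. Nothing at hand bears on why this step is so small.

The compounds shown leave open whether a ring carrying an amine or a carboxylic acid, or a longer open chain in place of the ring, would move the number at this carbonyl carbon beyond the scatter. The swap also appears on the core of compound 1 alone, so whether the same step would hold on another core remains an open question.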